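The compounds below may be only part of what the source reports. "The series", "measured", "known", "first", "only" and "open" are said of these compounds alone.

Compound 1, `CCCc1ccc(NC(=O)N[C@@H](C)c2ccccc2)cc1`, gives 76% in an ADME assay on the whole organism with Oryza sativa as the target, tested at 1 uM; a higher number here means a weaker effect of the compound at the concentration tested, a lower number a stronger effect.
Compound 2, `CCCCc1ccc(NC(=O)N[C@@H](C)c2ccccc2)cc1`, gives 72% in this assay.
Compound 3, `C[C@H](NC(=O)Nc1ccc(C(F)(F)F)cc1)c1ccccc1`, gives 94% in this assay.

Compound 3 has the highest number of the three, which on this read-out is the weakest effect: its step from compound 1 is a number 18 percentage points higher from compound 1 to compound 3 (beyond the scatter), and its step from compound 2 is a number 22 percentage points higher from compound 2 to compound 3 (beyond the scatter), both beyond the scatter. Compound 1 and compound 2 differ from each other only by a number 4 percentage points lower from compound 1 to compound 2 (within the scatter), which stays within the scatter.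

Compound 4, `CC(=O)c1ccc(NC(=O)N[C@@H](C)c2ccccc2)cc1`, is not yet measured in this assay. Within the data shown here, its change from compound 3 is acetyl in place of trifluoromethyl on an aromatic carbon, at the same aromatic carbon where the earlier steps swapped propyl or butyl for trifluoromethyl. Those two steps show that what sits on this carbon can shift the number by a modest amount, but neither involves acetyl, so they give no direction for this change. Compound 4 is therefore expected to land somewhere between the number of compound 3 and those of compound 1 and compound 2, with a step of a number 9 percentage points lower from compound 3 to compound 4 (within the scatter), and its estimate is 85% in this assay, within a range from 68% to 98%.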

Compound 4, a percentage reported as activity, at one concentration (the size of the read-out at that concentration, not a potency): 99%
The estimate for compound 4 lay 14 percentage points below the measured number, outside the stated range (above it).
By their numbers in this assay, from the lowest: compounds 2 and 1 (each within the scatter of the next); then compounds 3 and 4 (each within the scatter of the next).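

In this assay, on this aromatic carbon para to a large group, the exchange of trifluoromethyl for acetyl gives a number 5 percentage points higher from compound 3 to compound 4 (within the scatter) and so does not separate the two groups. Acetyl also stands apart from both saturated chains, with a number 27 percentage points higher from compound 2 to compound 4 (beyond the scatter) against butyl and a number 23 percentage points higher from compound 1 to compound 4 (beyond the scatter) against propyl, so among these four compounds the two chains give the stronger effect and acetyl joins trifluoromethyl on the weaker side. Acetyl carries a hydrogen-bond acceptor and trifluoromethyl carries none, so that count alone does not divide the two pairs here.

No measurement available here explains why the groups fall into these two pairs. Going by these compounds, it also remains open where other groups on this carbon would fall, such as an amine, a carboxylic acid or a chain longer than butyl, and whether either pair would stay together with such groups in the comparison.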